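Hydroxymethyl in Place of Hydrogen: From Compound 2 to Compound 4

This account rests on a few compounds, and the source may have more. Where it says the series, first, only, none or still open, it means among the compounds named here.

Three compounds have been measured in a functional assay on HeLa cells (Homo sapiens) for inhibition; on this read-out lower numbers stand for stronger inhibition and higher numbers for weaker inhibition:

compound 1, `Nc1ncnc2c1ncn2/C=C/C=O`, > 100000 nM, which is a limit of the assay and not a number
compound 2, `O=C/C=C/n1ccc(=O)[nH]c1=O`, 30000 nM
compound 3, `Cc1cn(COCCO)c(=O)n(/C=C/C=O)c1=O`, 20000 nM

Compound 1 sits at the limit of > 100000 nM in this assay, at which 1 of the 3 values shown sits. Among the two compounds with a number, compound 2 gives the higher one, but the gap to compound 3 lies within the usual scatter, so the two cannot be told apart on these data.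

Compound 4, `O=C/C=C/n1cc(CO)c(=O)[nH]c1=O`, has not yet been measured. It differs from compound 2 in one place: hydroxymethyl in place of hydrogen on an aromatic carbon. Going by the values given here, no step between two measured compounds carries this change, so there is nothing here to set its size. With only a small group entering at the ring carbon, the expected step from compound 2 to compound 4 in this assay is no change at the digits printed from compound 2 to compound 4 (within the scatter), that is, none beyond the scatter. For compound 4 the estimate in this assay is therefore 30000 nM, with a range from 10000 nM to 90000 nM.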

Compound 4, half-maximal inhibitory concentration: > 100000 nM
Compound 4: only a limit was reported; the forecaster's own chance of this, stated with the estimate: 20%; middle value at least 3.3-fold (0.52 log units) away from the limit.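

In this assay, hydroxymethyl in place of hydrogen on the aromatic carbon two atoms from the ring nitrogen gives an at least 3.3-fold higher number from compound 2 to compound 4 (0.52 log units; beyond the scatter), the first step shown at this position, and it shows that this position does not accept the change without a loss on this read-out. Compound 4 gives > 100000 nM, which is a limit of the assay and not a number, so the step has a lower end only and no upper one. This is the second value shown at that limit: the limit of > 100000 nM in this assay, at which 2 of the 4 values shown sit.

Going by these compounds, what stays open is whether any group entering at this aromatic carbon has the same outcome or whether it is the hydroxymethyl itself that matters. A methoxymethyl group, an aminomethyl group or a single fluorine atom at this carbon on the core of compound 2 would bear on that question.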